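A few compounds are considered here, and "the series" means these few. Any claim that something is new, unique, unknown or untested is made for them only; others in the source may bear on it.

- Compound 1 `O=C(Nc1ccc(Cl)cc1)c1ccnc2cc(Br)ccc12`: > 20000 nM (a limit of the assay, not a number)
- Compound 2 `O=C(Nc1ccc(F)cc1F)c1cc(=O)[nH]c2cc(Br)ccc12`: > 20000 nM (a limit of the assay, not a number)
- Compound 3 `O=C(Nc1cc(F)cc(F)c1)c1cc(=O)[nH]c2cc(Cl)ccc12`: 9000 nM

In a functional assay on KYSE-70 cells for antiproliferative activity against KYSE-70 cell line (Homo sapiens), read by MTT assay, with a stated time of 72 h (a higher number here means a weaker inhibitor, a lower number a stronger inhibitor), compound 3 gives 9000 nM. Within the data shown here, this is the only true number so far, since the other two results are limits. Compound 4 `O=C(Nc1cc(F)cc(F)c1)c1cc(=O)[nH]c2cc(O)ccc12` changes one group of compound 3: hydroxy in place of chloro on an aromatic carbon. Among the measured compounds shown here, no measured pair of compounds shows this swap, so any forecast is loose. A modest move toward weaker activity is expected, and the result could also come back as a limit. The estimated change is a 1.7-fold higher number from compound 3 to compound 4 (0.22 log units; within the scatter). The expected value for compound 4 is 15000 nM, within an estimated range of 6000 nM to 35000 nM.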

Compound 4, half-maximal inhibitory concentration: > 20000 nM
Compound 4: a limit, no number; the forecaster's own chance of this, stated with the estimate: 45%; middle value at least 1.3-fold (0.12 log units) from the limit.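

In this assay, hydroxy in place of chloro on this aromatic carbon gives an at least 2.2-fold higher number from compound 3 to compound 4 (0.34 log units; beyond the scatter), the first readable sign that activity depends on what sits at this position. Compound 4 rests at a limit of the assay, not a number, so the true size of the loss stays unknown, since the readings stop at that limit: the limit of > 20000 nM in this assay, at which 3 of the 4 values shown sit.

The compounds shown leave open how a methoxy group or an amine on this same carbon would read. They also leave open whether any group here could give stronger activity than chloro.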